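This account rests on a few compounds, and the source may have more. Where it says the series, first, only, none or still open, it means among the compounds named here.

Compound 1 `CCN(CC)CN1C(=O)/C(=N/NC(=S)Nc2ccc(Cl)cc2)c2ccccc21`: 400 nM
Compound 2 `CCN(CC)CN1C(=O)/C(=N/NC(=S)Nc2ccc(OC)cc2)c2ccccc21`: 9200 nM

In an ADME assay on MDCK cells (Canis lupus familiaris) for cytotoxicity (on this read-out higher numbers stand for lower toxicity in this test and lower numbers for higher toxicity in this test), compound 1 stands lowest of the two measured compounds at 400 nM. Compound 3 `CCN(CC)CN1C(=O)/C(=N/NC(=S)Nc2ccc(Cl)cc2)c2cc(Cl)ccc21` differs from it by one change: chloro in place of hydrogen on an aromatic carbon. Among the measured compounds shown here, the only measured step, a 23-fold higher number from compound 1 to compound 2 (1.36 log units; beyond the scatter), is methoxy in place of chloro on an aromatic carbon. That is a different change, so it bears only loosely and shows that this number can move far. For the measured compounds named here, no measured step adds chloro in place of hydrogen, so only a small shift toward lower numbers is expected, with wide uncertainty. The expected step is a 1.3-fold lower number from compound 1 to compound 3 (0.12 log units; within the scatter). For compound 3 the estimated value is 300 nM, with an expected range of 100 nM to 900 nM.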

Compound 3, half-maximal cytotoxic concentration: 2400 nM
Compound 3: middle estimate off by 8.0-fold (0.90 log units), on the low side; the measured number lies above the stated range.
By their numbers in this assay, from the lowest: compound 1; then compound 3; then compound 2.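

In this assay, the earlier step changed a different place, and this result shows that the six-membered aromatic ring of carbon only, part of the fused system, also moves the number: chloro in place of hydrogen there gives a 6.0-fold higher number from compound 1 to compound 3 (0.78 log units; beyond the scatter) and so lower toxicity in this test. A single added chlorine is enough for a step beyond the scatter. Nothing shown accounts for this step.

On these data alone, whether fluoro or a carboxylic acid at this place would move the number the same way stays open. So does whether chloro here would have the same effect in compound 2.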